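A few compounds are considered here, and "the series" means these few. Any claim that something is new, unique, unknown or untested is made for them only; others in the source may bear on it.

Measured in a functional assay on A549 cells (Homo sapiens) for antiproliferative activity, read by MTT assay, with a stated time of 48 h; a lower number here means a stronger inhibitor, a higher number a weaker inhibitor:
- Compound 1 `Cc1ccc2[nH]c(-c3cn(-c4ccccc4)nc3-c3ccccc3)nc2c1`: 3610 nM
- Compound 2 `COc1ccc2[nH]c(-c3cn(-c4ccccc4)nc3-c3ccc(Cl)cc3)nc2c1`: 2420 nM

Compound 2, at 2420 nM, lies within the scatter of compound 1, so the two values show no separation. Compound 3 `Cc1ccc2[nH]c(-c3cn(-c4ccccc4)nc3-c3ccc(Cl)cc3)nc2c1` is not yet measured. It has methyl in place of methoxy on an aromatic carbon relative to compound 2: methyl in place of methoxy on an aromatic carbon. Among the compounds with values here, no measured pair isolates this change. Compound 1, which also carries methyl, gives 3610 nM, so no step beyond the scatter is expected in this assay, and no direction is favoured. The expected step is a 1.1-fold higher number from compound 2 to compound 3 (0.03 log units; within the scatter). The estimate for compound 3 is 2600 nM, with an expected range of 1300 nM to 5000 nM.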

Compound 3, half-maximal inhibitory concentration: 4640 nM
Compound 3: the middle estimate sits 1.8-fold (0.25 log units) below what was measured, and the stated range covers the measured number.
By their numbers in this assay, from the lowest: compounds 2, 1 and 3 (each within the scatter of the next).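

In this assay, the series now gives its first single-change comparisons: a 1.9-fold higher number from compound 2 to compound 3 (0.28 log units; within the scatter) for methyl in place of methoxy on an aromatic carbon, and a 1.3-fold higher number from compound 1 to compound 3 (0.11 log units; within the scatter) for chloro in place of hydrogen on an aromatic carbon. Both steps lie within the scatter, so neither change is resolved from repeat variation at this position or the other. No supporting data bear on these numbers.

From the compounds shown here alone, whether an amine, a carboxylic acid or a longer alkoxy chain in place of methoxy would give a step beyond the scatter remains open. Also open, going by these compounds, is whether the methoxy-to-methyl step holds when chloro is replaced by hydrogen.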